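The source may report more compounds than this note shows. Statements on the series, on what has been measured and on what is new or still open speak of the compounds shown alone.

In an assay on isolated protein for displacement of a labelled ligand from metabotropic glutamate receptor 5 (Homo sapiens), with a stated time of 60 min, tested at 1 uM (a higher number here means more inhibition at the concentration tested (going by the name of the read-out), a lower number less inhibition), the measured compounds are:

Compound 1 `CC1CCN(c2c(S(=O)(=O)c3cc(Cl)cc(Cl)c3)cnc3ccc(F)cc23)CC1` gives 69%.
Compound 2 `COc1ccc2ncc(S(=O)(=O)c3ccc(Cl)c(Cl)c3)c(N3CCC(C)CC3)c2c1` gives 87%.
Compound 3 `COc1ccc2ncc(S(=O)(=O)c3ccc(F)cc3)c(N3CCC(C)CC3)c2c1` gives 27%.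

Compound 3 stands lowest of these three numbers, with compound 1 nearest and compound 2 furthest above it. Compound 4 `COc1ccc2ncc(S(=O)(=O)c3cc(Cl)cc(Cl)c3)c(N3CCC(C)CC3)c2c1` arises from compound 3 by one change: 3,5-dichlorophenyl in place of 4-fluorophenyl on a sulfonyl sulfur. Among the compounds with values here, one measured step bears on this. The drop a number 60 percentage points lower from compound 2 to compound 3 (beyond the scatter) came with a dichlorophenyl giving way to 4-fluorophenyl on the sulfonyl sulfur; the step to compound 4 reverses that kind of change. Compound 1, which carries the same 3,5-dichlorophenyl on a different core, gives 69%. A large rise is therefore expected in this assay.

Compound 4 is expected to give about 75%, in a range of 55% to 92%. That expected step is a number 48 percentage points higher from compound 3 to compound 4 (beyond the scatter).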

Compound 4, a percentage reported as inhibition, at one concentration (the size of the read-out at that concentration, not a potency): 87%
Compound 4: the middle estimate sits 12 percentage points below what was measured, within the range that was stated.
By their numbers in this assay, from the lowest: compound 3; then compound 1; then compounds 2 and 4 (each within the scatter of the next).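

In this assay the rise is not tied to one chlorine pattern: 3,5-dichlorophenyl in place of 4-fluorophenyl on the sulfonyl sulfur gives a number 60 percentage points higher from compound 3 to compound 4 (beyond the scatter). Swapping 3,4-dichlorophenyl for 3,5-dichlorophenyl gives no change at the digits printed from compound 2 to compound 4 (within the scatter), so this assay does not separate these two groups. With 3,5-dichlorophenyl held constant, methoxy in place of fluoro on an aromatic carbon gives a number 18 percentage points higher from compound 1 to compound 4 (beyond the scatter), showing that this second site also matters. Nothing measured here gives a reason for these steps. On these data alone, whether a 3-chlorophenyl or a 3,5-dimethylphenyl on the sulfonyl sulfur would keep the number this high remains open.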